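Swapping the benzothiophene ring for a nitrogen-bearing analogue

The compounds below may be only part of what the source reports. "The series", "measured", "known", "first", "only" and "open" are said of these compounds alone.

Measured compounds in an assay on isolated protein for agonist activity at Bile acid receptor (Homo sapiens), read by FRET, with a stated time of 2 h; a higher number here means that more compound is needed for the effect, a lower number that less compound is needed:
compound 1 `CC(C)c1onc(-c2c(Cl)cccc2Cl)c1COc1ccc(Cn2ccc3ccc(C(=O)O)cc32)cc1`: 1000 nM
compound 2 `CC(C)c1onc(-c2c(Cl)cccc2Cl)c1COc1ccc(Sc2cccc3sc(C(=O)O)cc23)cc1`: 190 nM
compound 3 `CC(C)c1onc(-c2c(Cl)cccc2Cl)c1COc1ccc(-c2ccc3sc(C(=O)O)cc3c2)cc1`: 250 nM

Of the three numbers, compound 3 holds the second highest. Its gap to compound 2 lies within the scatter, so the two cannot be ordered; its gap to compound 1 lies beyond the scatter, compound 1 needing the higher concentration. Compound 4 `CC(C)c1onc(-c2c(Cl)cccc2Cl)c1COc1ccc(-c2ccc3sc(C(=O)O)cc3n2)cc1` differs from compound 3 by the change (a group of 12 heavy atoms (8 carbon, 1 nitrogen, 2 oxygen, 1 sulfur; one five-membered aromatic ring with 1 hetero atom, one six-membered aromatic ring with 1 hetero atom) in place of a group of 12 heavy atoms (9 carbon, 2 oxygen, 1 sulfur; one five-membered aromatic ring with 1 hetero atom, one six-membered aromatic ring of carbon only), on an aromatic carbon). Among the measured compounds shown here, no measured pair shows this kind of step, so the direction rests on nothing firm; the change is expected to stay within the scatter, with a 1.2-fold higher number from compound 3 to compound 4 (0.08 log units; within the scatter). For compound 4 the estimate in this assay is 300 nM, within 100 nM to 900 nM.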

Compound 4, half-maximal effective concentration: 670 nM
Beside the measured number, compound 4's estimate is 2.2-fold (0.35 log units) below it; measured number inside the range.
By their numbers in this assay, from the lowest: compounds 2 and 3 (each within the scatter of the next); then compounds 4 and 1 (each within the scatter of the next).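

In this assay, among the compounds shown here, putting a ring nitrogen into the 2-carboxy-1-benzothiophen-5-yl group gives a 2.7-fold higher number from compound 3 to compound 4 (0.43 log units; beyond the scatter), the only single-place step in this set. This group, para to a large group, is therefore not indifferent to this change, although the heavy-atom count stays the same. Nothing measured here accounts for the step.

From the compounds shown here alone, it remains open whether a nitrogen elsewhere in that six-membered ring would give a similar step. Going by these compounds, it is also open whether an amine or a methoxy group on the nitrogen-bearing ring would bring the number back to that of compound 3.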